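Nitro replacement on the methoxy-bearing ring of compound 1

This account rests on a few compounds, and the source may have more. Where it says the series, first, only, none or still open, it means among the compounds named here.

Measured so far:
compound 1 `COc1cc2ncnc(-n3nc(-c4ccccn4)nc3N)c2cc1[N+](=O)[O-]` — 31100 nM
compound 2 `Nc1nc(-c2ccccn2)nn1-c1ncnc2cc(N3CCNCC3)c([N+](=O)[O-])cc12` — > 40000 nM
compound 3 `COc1cc2ncnc(-n3cnc(-c4ccccn4)n3)c2cc1OC` — 5300 nM

In an assay on MCF7 cells for inhibition of Serine-protein kinase ATM (Homo sapiens), read by immunofluorescence, with a stated time of 1 h (a higher number here means a weaker inhibitor, a lower number a stronger inhibitor), compound 1 gives 31100 nM, the highest of the two numbers shown. Compound 3 gives 5300 nM, a lower number. Compound 2 reaches only a limit of the assay, > 40000 nM, which is the limit of > 40000 nM in this assay, at which 1 of the 3 values shown sits. Within the data shown here, the one step between measured compounds, an at least 1.2-fold higher number from compound 1 to compound 2 (0.10 log units; that floor lies within the scatter), concerns a different position and a different exchange, so nothing measured bears directly on the change to compound 4 `COc1cc2ncnc(-n3nc(-c4ccccn4)nc3N)c2cc1OCCNC(=O)OC(C)(C)C`: 2-((tert-butoxycarbonyl)amino)ethoxy in place of nitro on an aromatic carbon. Among the measured compounds shown here, with no comparable step, no direction beyond the scatter can be argued from the data. For compound 4 the expected outcome in this assay is 18000 nM, within 4000 nM to 60000 nM. This estimate means a step of a 1.7-fold lower number from compound 1 to compound 4 (0.24 log units; within the scatter), held near the scatter for want of evidence.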

Compound 4, half-maximal inhibitory concentration: 800 nM
Estimate against measurement, compound 4: 23-fold (1.35 log units) above; measured number outside the range, below it.
By their numbers in this assay, from the lowest: compound 4; then compound 3; then compound 1. At a limit, above all of these: compound 2.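

At this position, ortho to a methoxy group, 2-((tert-butoxycarbonyl)amino)ethoxy in place of nitro gives a 39-fold lower number from compound 1 to compound 4 (1.59 log units; beyond the scatter) in this assay, so the position accepts a far larger chain with no ring and the number still falls. The step exchanges the whole group, so the loss of nitro and the arrival of the chain cannot be told apart. Nothing measured here accounts for the size of this step.

Open, on these data alone, is how much of the step belongs to the tert-butoxycarbonyl end of the chain. The free primary amine on the same ethoxy chain, a plain methoxy, or a longer chain at this position would test that.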